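The source may hold more compounds than are shown below. What is called first, only, known or untested is meant among the compounds shown, and "the series" means these compounds.

Compound 1 `COc1cc(C2CC(=NOC(=O)c3cccc(O)c3)CC(c3ccc(O)c(OC)c3)N2C)ccc1O` is tested in a functional assay on microsomes from liver (Rattus norvegicus, strain Wistar) for inhibition, read by spectrophotometry, with a stated time of 60 min (a lower number here means a stronger inhibitor, a higher number a weaker inhibitor), where compound 1 gives 25300 nM, the lowest of the three numbers measured. Compound 2 `COc1cc(C2CC(=NOC(=O)c3ccc(Br)cc3)CC(c3ccc(O)c(OC)c3)N2C)ccc1O` gives 112000 nM and compound 3 `COc1ccc(C(=O)ON=C2CC(c3ccc(O)c(OC)c3)N(C)C(c3ccc(O)c(OC)c3)C2)c(OC)c1` gives 52000 nM. Compound 4 `COc1ccc(C(=O)ON=C2CC(c3ccc(O)c(OC)c3)N(C)C(c3ccc(O)c(OC)c3)C2)cc1` has not yet been measured; it differs from compound 1 in one place: 4-methoxyphenyl in place of 3-hydroxyphenyl on a carbonyl carbon. Two measured steps start from the same 3-hydroxyphenyl group: a 4.4-fold higher number from compound 1 to compound 2 (0.65 log units; beyond the scatter) and a 2.1-fold higher number from compound 1 to compound 3 (0.31 log units; beyond the scatter). Both replacements of this group weakened inhibition by a modest amount. Replacing it by 4-methoxyphenyl is therefore expected to give a modest weakening too, as a 2.4-fold higher number from compound 1 to compound 4 (0.38 log units; beyond the scatter). Compound 4 is thus estimated at 60000 nM, with a likely range from 25000 nM to 150000 nM in this assay.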

Compound 4, half-maximal inhibitory concentration: 40000 nM
Estimate against measurement, compound 4: 1.5-fold (0.18 log units) above, within the range that was stated.
By their numbers in this assay, from the lowest: compounds 1, 4 and 3 (each within the scatter of the next, the first and the last beyond it); then compound 2.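

The 3-hydroxyphenyl group carries a hydrogen-bond donor and 4-methoxyphenyl carries none, yet this swap on the carbonyl carbon stays within the scatter (a 1.6-fold higher number from compound 1 to compound 4 (0.20 log units; within the scatter)), so inhibition here does not depend on that donor. Removing the second methoxy from the ring also makes no clear difference (a 1.3-fold lower number from compound 3 to compound 4 (0.11 log units; within the scatter)). Methoxy in place of bromo, however, gives a real gain (a 2.8-fold lower number from compound 2 to compound 4 (0.45 log units; beyond the scatter)).

Nothing shown here explains these differences. Going by these compounds, whether an amine or a carboxylic acid on this ring, or a longer chain in place of the methoxy, would keep or improve inhibition remains open.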